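A few compounds are considered here, and "the series" means these few. Any claim that something is new, unique, unknown or untested is made for them only; others in the source may bear on it.

Compound 1 `CC(=O)c1cc(-c2ccccc2)cc2cc(-c3ccc(F)cc3)[nH]c12`: > 100000 nM
Compound 2 `CC(=O)c1cc(/C=C/c2ccc(F)cc2)cc2cc(-c3ccccc3)[nH]c12`: 18500 nM

In a functional assay on MCF7 cells (Homo sapiens) for cytotoxicity, read by MTT assay, with a stated time of 2 days (on this read-out higher numbers stand for lower toxicity in this test and lower numbers for higher toxicity in this test), compound 1 gives only a limit, > 100000 nM, so no number is known for it. Going by the values given here, compound 2 gives 18500 nM in this assay, the only number among the two values shown. The other value sits at the limit of > 100000 nM in this assay, at which 1 of the 2 values shown sits. Compound 3 `CC(=O)c1cc(/C=C/c2ccc(F)cc2)cc2cc(-c3ccc(F)cc3)[nH]c12` differs from compound 2 by fluoro in place of hydrogen on an aromatic carbon. Among the compounds with values here, no measured pair shows this change, so its size is unknown from the data. Compound 3 is expected to stay close to compound 2, with the step of a 1.4-fold higher number from compound 2 to compound 3 (0.13 log units; within the scatter) not beyond the usual scatter. Compound 3 is estimated at 25000 nM, between 8000 nM and 80000 nM in this assay.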

Compound 3, concentration lethal to 50% of the cells: > 100000 nM
Compound 3 was reported as a limit; the forecaster's own chance of this, stated with the estimate: 15%; middle value at least 4.0-fold (0.60 log units) away from the limit.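

In this assay, changing phenyl to 4-fluorophenyl gives an at least 5.4-fold higher number from compound 2 to compound 3 (0.73 log units; beyond the scatter), so this single fluoro in place of hydrogen is enough to lower toxicity in this test. The value of compound 3 is a limit of the assay, not a number, so this step has a floor but no known full size: the limit of > 100000 nM in this assay, at which 2 of the 3 values shown sit. Compound 1 and compound 3 both stand as limits, and the step between them cannot be read.

On these data alone, whether a chloro, a methoxy or an amine at this same place would act like fluoro remains open.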